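The compounds below may be only part of what the source reports. "The series", "measured", "known", "first", "only" and "open" are said of these compounds alone.

Series notes. Compound 3 `Cc1cc(C(=O)N2CCCCc3ccccc32)ccc1CNC(=O)NCC(=O)N1CCCC1` gives the lowest number of the three measured, at 100 nM in a functional assay on HEK293 cells for agonist activity at Vasopressin V2 receptor (Homo sapiens), read by a luciferase reporter and cAMP accumulation; on this read-out lower numbers stand for an effect already at smaller amounts and higher numbers for an effect only at larger amounts of compound; compound 1 `Cc1cc(C(=O)N2CCCCc3ccccc32)ccc1CNC(=O)NCC(=O)OC(C)C` stands nearest with 140 nM, and compound 2 `Cc1cc(C(=O)N2CCCCc3ccccc32)ccc1CNC(=O)NCC(N)=O` furthest with 210 nM. The measured steps all change the group on the terminal carbonyl carbon: a 1.4-fold lower number from compound 1 to compound 3 (0.15 log units; within the scatter), a 2.1-fold lower number from compound 2 to compound 3 (0.32 log units; beyond the scatter), a 1.5-fold higher number from compound 1 to compound 2 (0.18 log units; within the scatter). Compound 4 `COC(=O)[C@@H]1CCCN1C(=O)NCc1ccc(C(=O)N2CCCCc3ccccc32)cc1C` differs from compound 3 by 2-(methoxycarbonyl)pyrrolidin-1-yl in place of (((pyrrolidin-1-yl)carbonyl)methyl)amino on a carbonyl carbon, a change one bond closer to the shared core than any measured step, and one that removes the hydrogen-bond donor counted there. For the measured compounds named here, no measured step covers this directly; the steps on record are small, so a small change in this assay in either direction is expected for compound 4, as a 1.6-fold higher number from compound 3 to compound 4 (0.20 log units; within the scatter). Compound 4 is therefore estimated at 160 nM, within 50 nM to 500 nM.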

Compound 4, half-maximal effective concentration: 100 nM
Estimate against measurement, compound 4: 1.6-fold (0.20 log units) above; low and high end bracket the measured number.
By their numbers in this assay, from the lowest: compounds 3, 4, 1 and 2 (each within the scatter of the next, the first and the last beyond it).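

Putting 2-(methoxycarbonyl)pyrrolidin-1-yl on this carbonyl carbon gives no change at the digits printed from compound 3 to compound 4 (within the scatter), so in this assay the position keeps its level with the hydrogen-bond donor of the leaving group gone and a defined stereocentre added. The same group gives a 2.1-fold lower number from compound 2 to compound 4 (0.32 log units; beyond the scatter) and a 1.4-fold lower number from compound 1 to compound 4 (0.15 log units; within the scatter), matching the standing of compound 3 against both earlier compounds. Nothing at hand accounts for this result. Open remain the opposite configuration at the stereocentre and a carboxylic acid in place of the methyl ester.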